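Replacing bromo with methoxy in the halogen series

A few compounds are considered here, and "the series" means these few. Any claim that something is new, unique, unknown or untested is made for them only; others in the source may bear on it.

Measured in a functional assay on FM3A cells (Mus musculus) for antiproliferative activity, with a stated time of 48 h; a higher number here means a weaker inhibitor, a lower number a stronger inhibitor:
- compound 1 `C=C(Br)C(=O)Nc1ccc(/C=C/C(=O)c2ccc(Cl)cc2)cc1`: 1300 nM
- compound 2 `C=C(Br)C(=O)Nc1ccc(/C=C/C(=O)c2ccc(Br)cc2)cc1`: 1100 nM
- compound 3 `C=C(Br)C(=O)Nc1ccc(/C=C/C(=O)c2ccc(I)cc2)cc1`: 8300 nM

At the low end of the numbers stand two compounds that the scatter cannot separate: a 1.2-fold lower number from compound 1 to compound 2 (0.07 log units; within the scatter). Compound 2 is one of them. For the measured compounds named here, the only step from it that goes beyond the scatter is a 7.5-fold higher number from compound 2 to compound 3 (0.88 log units; beyond the scatter), and the other iodo step is similar: a 6.4-fold higher number from compound 1 to compound 3 (0.81 log units; beyond the scatter).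

The next change leads to compound 4 `C=C(Br)C(=O)Nc1ccc(/C=C/C(=O)c2ccc(OC)cc2)cc1`, with methoxy in place of bromo on an aromatic carbon, para to a large group: methoxy in place of bromo on an aromatic carbon.

Going by the values given here, no measured step involves methoxy, so the three halogen steps give only a rough guide to size. They span a null exchange and modest iodo steps, and they offer no basis for a direction. The expected result in this assay is therefore a 1.2-fold higher number from compound 2 to compound 4 (0.07 log units; within the scatter), with a wide margin on both sides. For compound 4 the estimated value is 1300 nM, with an expected range of 350 nM to 5500 nM.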

Compound 4, half-maximal inhibitory concentration: 1200 nM
Estimate against measurement, compound 4: 1.1-fold (0.03 log units) above, within the range that was stated.
By their numbers in this assay, from the lowest: compounds 2, 4 and 1 (each within the scatter of the next); then compound 3.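

In this assay, for the compounds shown here, methoxy is the first group at this position that is not a halogen, and it falls with chloro and bromo (first a 1.1-fold higher number from compound 2 to compound 4 (0.04 log units; within the scatter), then a 1.1-fold lower number from compound 1 to compound 4 (0.03 log units; within the scatter)), although it brings two heavy atoms and a hydrogen-bond acceptor where bromo brings one heavy atom and no acceptor. Iodo alone stands apart (see a 6.9-fold lower number from compound 3 to compound 4 (0.84 log units; beyond the scatter)), so the division in this set does not run between halogen and non-halogen. Nothing available accounts for these values.

From the compounds shown here alone, whether an amine, a carboxylic acid or a longer chain such as ethoxy at this position would stay with compound 4 or fall nearer compound 3 remains open. Going by these compounds, the rest of the core of compound 1 is the same throughout, so it is also open whether this pattern would hold with a change elsewhere in the molecule.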